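Methoxy in place of chloro: expected whole-organism toxicity

The source may report more compounds than this note shows. Statements on the series, on what has been measured and on what is new or still open speak of the compounds shown alone.

Among the compounds with values here, compound 1 `C=CCNC(=O)/C(C)=C(/C)c1ccc(Cl)cc1` stands highest of the two numbers so far in a toxicity assay on the whole organism (strain Icem-CET (SPF Caw)) for cytotoxicity, with Mus musculus as the target (a lower number here means that less compound is needed, a higher number that more compound is needed for the effect), where compound 1 gives 180 mg/kg. Its nearest neighbour, compound 2 `C#CCNC(=O)/C(C)=C(\C)c1ccc(Cl)cc1`, gives 60 mg/kg in this assay, a lower number beyond the scatter. Compound 3 `C=CCNC(=O)/C(C)=C(/C)c1ccc(OC)cc1` differs from compound 1 in a single change: methoxy in place of chloro on an aromatic carbon. Within the data shown here, no measured pair shows this change. In this assay the step from compound 1 to compound 3 is expected to be a 1.1-fold higher number from compound 1 to compound 3 (0.05 log units; within the scatter), none beyond the scatter. Compound 3 is therefore estimated at 200 mg/kg, with a range from 90 mg/kg to 450 mg/kg.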

Compound 3, dose for half-maximal effect: 280 mg/kg
Beside the measured number, compound 3's estimate is 1.4-fold (0.15 log units) below it; the range from low to high includes it.
By their numbers in this assay, from the lowest: compound 2; then compounds 1 and 3 (each within the scatter of the next).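

In this assay, within the data shown here, the exchange of chloro for methoxy on an aromatic carbon, para to a large group, gives a 1.6-fold higher number from compound 1 to compound 3 (0.19 log units; within the scatter), the first measured step at this position. On the core of compound 1, this single exchange therefore leaves the number within the scatter, so the two compounds cannot be told apart here. Nothing available explains this result. As far as these compounds go, what an amine, a carboxylic acid or a fluoro group at this position would give in this assay remains open, as does whether methoxy in place of chloro gives a similar step on the core of compound 2.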